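Extending the Acrylamide of Compound 1 by One Carbon

The source may report more compounds than this note shows. Statements on the series, on what has been measured and on what is new or still open speak of the compounds shown alone.

Measured compounds:
compound 1 `C=CC(=O)Nc1cccc(Nc2ncnc(Nc3ccc(C(=O)N4CCCCC4)cc3)n2)c1` gives 5140 nM
compound 2 `C=CC(=O)Nc1cccc(Nc2ncnc(Nc3ccc(-c4cccnc4)cc3)n2)c1` gives 12400 nM
compound 3 `C=CC(=O)Nc1cccc(Nc2ncnc(Nc3ccc(C(=O)Nc4ccccn4)cc3)n2)c1` gives 15600 nM

Three compounds on a shared core were tested in a functional assay on Raji cells (Homo sapiens) for antiproliferative activity, read by CCK-8 assay, with a stated time of 24 h; on this read-out lower numbers stand for stronger inhibition and higher numbers for weaker inhibition. Compound 1 stands with the lowest number of the three. The step of a 2.4-fold higher number from compound 1 to compound 2 (0.38 log units; beyond the scatter) and the step of a 3.0-fold higher number from compound 1 to compound 3 (0.48 log units; beyond the scatter) both lie beyond the scatter, whereas the step of a 1.3-fold higher number from compound 2 to compound 3 (0.10 log units; within the scatter) lies within it, so compound 2 and compound 3 cannot be ordered against each other.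

The unmeasured compound 4 `CC#CC(=O)Nc1cccc(Nc2ncnc(Nc3ccc(C(=O)N4CCCCC4)cc3)n2)c1` differs from compound 1 in a single place: prop-1-yn-1-yl in place of vinyl on a carbonyl carbon. None of the three measured steps bears on this position. All of them alter the substituent on the other aromatic ring of the core and leave the vinylcarbonyl amide untouched, so the data give no direct guide to the size or direction of this change.

For the measured compounds named here, with no comparable step among the measured compounds, the expectation for compound 4 rests on compound 1 alone, and the estimated step of a 1.4-fold higher number from compound 1 to compound 4 (0.13 log units; within the scatter) is kept small, with the direction left open. In this assay compound 4 is therefore expected to give about 7000 nM, with a range from 2500 nM to 20000 nM.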

Compound 4, half-maximal inhibitory concentration: 4620 nM
For compound 4 the middle estimate is 1.5-fold (0.18 log units) above the measured one; the range from low to high includes it.
By their numbers in this assay, from the lowest: compounds 4 and 1 (each within the scatter of the next); then compounds 2 and 3 (each within the scatter of the next).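

In this assay, the step at the carbonyl carbon whose other neighbour is the amide-type nitrogen, prop-1-yn-1-yl in place of vinyl, is (a 1.1-fold lower number from compound 1 to compound 4 (0.05 log units; within the scatter)), so compound 1 and compound 4 cannot be ordered against each other. This is the only step shown that touches this position, since the earlier steps all altered the substituent on the other aromatic ring of the shared core. It shows that, on the core of compound 1, a chain of three carbons with a triple bond can stand where a chain of two carbons with a double bond stood, with no change in the read-out beyond the scatter, and no measurement shown accounts for this result.

The compounds shown leave open whether an ethyl group, a longer chain or a chain carrying an amine at this carbonyl carbon would leave the number just as it is or shift it clearly in either direction. They also leave open whether prop-1-yn-1-yl in place of vinyl would give the same result with the substituents of compound 2 or compound 3 on the other ring.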